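Chlorine Added to Compound 2's Core: Expected Growth Inhibition

The source may hold more compounds than are shown below. What is called first, only, known or untested is meant among the compounds shown, and "the series" means these compounds.

Measured so far:
compound 1, `ClCc1cccc(Cn2cnc3ncnc(Cl)c32)c1`: 4070 nM
compound 2, `ClCc1ccccc1Cn1cnc2ncnc(Cl)c21`: 12900 nM
compound 3, `ClCc1cccc(Cn2cnc3nc(Cl)nc(Cl)c32)c1`: 2880 nM

All three were tested in a functional assay on 786-0 cells (Homo sapiens) for cytotoxicity, read by sulforhodamine B assay, with a stated time of 48 h; on this read-out higher numbers stand for weaker inhibition of growth and lower numbers for stronger inhibition of growth. Compound 2 gives the highest number of the three, so its inhibition of growth is the weakest. Compound 1 and compound 2 contain the same atoms joined differently; how their two cores differ is not broken down here.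

Compound 3 arises from compound 1 by one change, (chloro in place of hydrogen on an aromatic carbon), and the step of a 1.4-fold lower number from compound 1 to compound 3 (0.15 log units; within the scatter) is small. Compound 4, `ClCc1ccccc1Cn1cnc2nc(Cl)nc(Cl)c21`, arises from compound 2 by the same change, (chloro in place of hydrogen on an aromatic carbon), on a core that differs. Because the step of a 1.4-fold lower number from compound 1 to compound 3 (0.15 log units; within the scatter) is small, compound 4 is expected to stay close to compound 2, with a step of a 1.4-fold lower number from compound 2 to compound 4 (0.15 log units; within the scatter) in this assay. The estimate for compound 4 is 9200 nM, between 4500 nM and 19000 nM.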

Compound 4, concentration for total growth inhibition: 7070 nM
Beside the measured number, compound 4's estimate is 1.3-fold (0.11 log units) above it, within the range that was stated.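

The swap of hydrogen for chloro on the second core gives a 1.8-fold lower number from compound 2 to compound 4 (0.26 log units; within the scatter) in this assay, so on neither core does this change move the number beyond the usual scatter. Set side by side, the two steps agree: the same change on two cores in this assay, a 1.4-fold lower number (0.15 log units; within the scatter) from compound 1 to compound 3 and a 1.8-fold lower number (0.26 log units; within the scatter) from compound 2 to compound 4, 1.3-fold (0.11 log units) apart, within the scatter of two such steps. This shows that a small step carried over between these two cores, but it does not show that the chloro group really alters growth inhibition, and two cores say nothing about how the change would behave on any other core.

Only hydrogen and chloro appear on this aromatic carbon between two ring nitrogen atoms. Going by these compounds, whether an amine or a methoxy group there would give a step beyond the scatter remains open.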